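The compounds below may be only part of what the source reports. "The series", "measured", "known", "first", "only" and "open" are said of these compounds alone.

In an ADME assay on the whole organism for pharmacokinetics, with Mus musculus as the target, at a dose of 3 mg/kg by the intravenous route (on this read-out higher numbers stand for fast clearance and lower numbers for slow clearance), compound 1 `CCC[C@H](C)Nc1ncc2c(-c3ccc(CN4CCCN(C)CC4)cc3)cn([C@H]3CC[C@H](O)CC3)c2n1` gives 29 mL/min/kg. Compound 2 `CCC[C@H](C)Nc1ncc2c(-c3ccc(S(=O)(=O)N4CCN(C)CC4)cc3F)cn([C@H]3CC[C@H](O)CC3)c2n1` gives 50 mL/min/kg. For the measured compounds named here, these two values lie within the scatter of each other, so compound 1 stands level with the only other measured compound. Compound 3 `CCC[C@H](C)Nc1ncc2c(-c3ccc(CNCCN(CC)CC)cc3)cn([C@H]3CC[C@H](O)CC3)c2n1` has not yet been measured. It keeps the core of compound 1 and differs at one place: (2-(diethylamino)ethyl)amino in place of 4-methyl-1,4-diazepan-1-yl on a saturated chain carbon bound to an aromatic carbon. In words, this is (2-(diethylamino)ethyl)amino in place of 4-methyl-1,4-diazepan-1-yl on a saturated chain carbon bound to an aromatic carbon. Going by the values given here, no measured pair differs in one place, so the data give no direct size for such a change. The expected step of a 1.2-fold higher number from compound 1 to compound 3 (0.08 log units; within the scatter) is therefore none beyond the scatter, with no firm direction. For compound 3 the estimated clearance in this assay is 35 mL/min/kg, with an expected range of 18 mL/min/kg to 65 mL/min/kg.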

Compound 3, clearance: 54 mL/min/kg
Beside the measured number, compound 3's estimate is 1.5-fold (0.19 log units) below it; the measured number falls inside the stated range.
By their numbers in this assay, from the lowest: compounds 1, 2 and 3 (each within the scatter of the next).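

For the compounds shown here, compound 1 and compound 3 are the first pair that differs in one place, so this assay now gives a direct size for a change on a saturated chain carbon bound to an aromatic carbon: a 1.9-fold higher number from compound 1 to compound 3 (0.27 log units; within the scatter) is the step for (2-(diethylamino)ethyl)amino in place of 4-methyl-1,4-diazepan-1-yl. Replacing the seven-membered ring with an open chain at this place therefore gives a step within the scatter on this read-out, and this single pair sets no direction. No evidence at hand bears on this result.

As far as these compounds go, whether a morpholin-4-yl group or a dimethylamino group on the same carbon would give a step beyond the scatter remains open. Also open, from the compounds shown here alone, is whether a longer chain between the two nitrogens would do so.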